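Microsomal half-life in an oxazole-piperidine carboxamide series

The compounds below may be only part of what the source reports. "The series", "measured", "known", "first", "only" and "open" are said of these compounds alone.

Within the data shown here, the three measured members share a core with a five-membered aromatic ring carrying a methyl group and an aryl group. Compound 1 `Cc1oc(-c2c(Cl)cccc2Cl)nc1CN1CCC(C(=O)NCCCN2C[C@H](C)C[C@H](C)C2)CC1` bears a 2,6-dichlorophenyl on that ring. In an ADME assay on microsomes from liver (Rattus norvegicus) for metabolic stability, read by LC-MS, using NADPH, at 37 degrees C (a higher number here means that the compound lasts longer, a lower number that the compound disappears faster), compound 1 gives 0.0483 h. Compound 3 `Cc1cccc(Cl)c1-c1nc(CN2CCC(C(=O)NCCCN3CCCC(C)C3)CC2)c(C)o1` gives 0.09 h in this assay, and its value sits within the scatter of that of compound 1, so the two cannot be ordered. Compound 2 `Cc1ccccc1-c1nc(CN2CCC(C(=O)NCCCCN3C[C@H](C)C[C@H](C)C3)CC2)c(C)o1` gives 0.2 h in this assay, a higher number that lies beyond the scatter relative to compound 1; it also differs in the length of the chain and in the aryl group, so no single change accounts for it.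

Compound 4 `Cc1cccc(C)c1-c1nc(CN2CCC(C(=O)NCCCN3C[C@H](C)C[C@H](C)C3)CC2)c(C)o1` has not been measured in this assay. It is obtained from compound 1 by one change: 2,6-dimethylphenyl in place of 2,6-dichlorophenyl on an aromatic carbon. Among the measured compounds shown here, no pair of measured compounds isolates this change, so no measured step can be quoted for it. The expectation is for a step from compound 1 to compound 4 of a 1.4-fold higher number from compound 1 to compound 4 (0.16 log units; within the scatter) in this assay, which is within the scatter and not a clear change in either direction. For compound 4 in this assay the estimate is 0.07 h, with a range from 0.03 h to 0.17 h.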

Compound 4, half-life: 0.0517 h
For compound 4 the middle estimate is 1.4-fold (0.13 log units) above the measured one, within the range that was stated.
By their numbers in this assay, from the lowest: compounds 1, 4 and 3 (each within the scatter of the next); then compound 2.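

Among these compounds, compound 1 and compound 4 form the first pair that isolates a single change at this position, on an aromatic carbon of a five-membered aromatic ring with 1 nitrogen and 1 oxygen. With the rest of the structure held constant, 2,6-dimethylphenyl in place of 2,6-dichlorophenyl gives a 1.1-fold higher number from compound 1 to compound 4 (0.03 log units; within the scatter) in this assay, so the two groups, which have the same count of heavy atoms, cannot be told apart on half-life at this place. The compounds offer no independent measurement that would speak to the reason for this result.

The compounds shown leave open whether an unsubstituted phenyl, a 2,6-difluorophenyl or a pyridine ring at this place would read the same as these two groups, or whether a carboxylic acid on the aryl ring would separate from them. Also open, as far as these compounds go, is whether the same exchange of chlorine for methyl reads alike on a longer chain or with another amine in place of the dimethylpiperidine at the end of the chain.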